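Compound 4: swapping methyl for chloro

The compounds below may be only part of what the source reports. "The series", "measured", "known", "first", "only" and "open" are said of these compounds alone.

In a functional assay on A-375 cells (Homo sapiens) for cytotoxicity, read by CCK-8 assay, with a stated time of 24 h (on this read-out higher numbers stand for weaker inhibition and lower numbers for stronger inhibition), three compounds have been measured:
Compound 1 `COc1ccccc1Oc1c(N)nc(-c2cccc(C)c2)nc1Cl`: 65300 nM
Compound 2 `COc1cccc(-c2nc(N)c(Oc3ccccc3OC)c(Cl)n2)c1`: 24600 nM
Compound 3 `COc1ccccc1Oc1c(N)nc(-c2cccc(C)c2)nc1OCCO`: 1380 nM

Compound 3 has the lowest number of the three, which makes it the strongest inhibitor so far. Compound 4 `COc1ccccc1Oc1c(N)nc(-c2cccc(Cl)c2)nc1OCCO` keeps its 2-hydroxyethoxy and alters one group: chloro in place of methyl on an aromatic carbon. Within the data shown here, two measured steps bear on this. Replacing the same methyl with methoxy gave a 2.7-fold lower number from compound 1 to compound 2 (0.42 log units; beyond the scatter), a modest change. Putting 2-hydroxyethoxy in place of chloro gave a 47-fold lower number from compound 1 to compound 3 (1.68 log units; beyond the scatter), a large change at a different place, and compound 4 retains that group. Among the measured compounds shown here, no measured pair shows methyl replaced by chloro directly, so the guide is indirect. In this assay a small step is therefore expected, perhaps slightly downward and possibly within the scatter. The estimate means a 1.3-fold lower number from compound 3 to compound 4 (0.10 log units; within the scatter) as the expected step. For compound 4 the estimated value is 1100 nM, with an expected range from 350 nM to 3500 nM.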

Compound 4, half-maximal inhibitory concentration: 30200 nM
Beside the measured number, compound 4's estimate is 27-fold (1.44 log units) below it, and the stated range ends below it.
By their numbers in this assay, from the lowest: compound 3; then compounds 2 and 4 (each within the scatter of the next); then compound 1.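

Within this assay, turning the 3-methylphenyl of compound 3 into the 3-chlorophenyl of compound 4 gives a 22-fold higher number from compound 3 to compound 4 (1.34 log units; beyond the scatter), even though only one heavy atom is exchanged for another and the counts of hydrogen-bond donors and acceptors stay the same. Among these compounds, the only earlier change at this place, a 2.7-fold lower number from compound 1 to compound 2 (0.42 log units; beyond the scatter) with methoxy entering for methyl, was modest and went the other way, though that step was measured with chloro rather than 2-hydroxyethoxy on the core, so this position can clearly move the number in either direction and by very different amounts. Nothing measured here accounts for the size of this step.

The compounds shown leave open how methoxy would read at this place with 2-hydroxyethoxy kept. They also leave open what fluoro, trifluoromethyl or an amine would do there.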